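This account rests on a few compounds, and the source may have more. Where it says the series, first, only, none or still open, it means among the compounds named here.

Of the compounds shown here, two on a shared core have been measured in an assay on HEK293 cells for inhibition of Voltage-dependent T-type calcium channel subunit alpha-1G (Homo sapiens); a lower number here means a stronger inhibitor, a higher number a weaker inhibitor. Compound 1 `NCCCCCNC1=Nc2ccccc2C(CC(=O)NCc2ccccc2)N1c1ccc(-c2ccccc2)cc1` gives 130 nM in this assay. Compound 2 `COC(=O)CC1c2ccccc2N=C(NCCCCCNC(=O)OC(C)(C)C)N1c1ccc(-c2ccccc2)cc1` gives 680 nM in this assay, the higher of the two numbers, a gap beyond the usual scatter; the two structures differ in more than one place, so only the two values themselves can be compared. Compound 3 `CC(C)(C)OC(=O)NCCCCCNC1=Nc2ccccc2C(CC(=O)NCc2ccccc2)N1c1ccc(-c2ccccc2)cc1` differs from compound 2 in one place: benzylamino in place of methoxy on a carbonyl carbon. Within the data shown here, no single-change step is available, yet compound 1 carries the same benzylcarbamoyl group and gives 130 nM, so a moderate step downward is expected for compound 3, estimated as a 2.3-fold lower number from compound 2 to compound 3 (0.36 log units; beyond the scatter). Compound 3 is therefore expected to give about 300 nM in this assay, within 100 nM to 900 nM.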

Compound 3, half-maximal inhibitory concentration: 160 nM
Beside the measured number, compound 3's estimate is 1.9-fold (0.27 log units) above it, and the stated range covers the measured number.
By their numbers in this assay, from the lowest: compounds 1 and 3 (each within the scatter of the next); then compound 2.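

Benzylamino in place of methoxy on a carbonyl carbon gives a 4.3-fold lower number from compound 2 to compound 3 (0.63 log units; beyond the scatter) in this assay, so this change now has a direct single-change reading. On the amine nitrogen, tert-butoxycarbonyl in place of hydrogen gives a 1.2-fold higher number from compound 1 to compound 3 (0.09 log units; within the scatter) and leaves the two values inseparable. Nothing measured here explains either step.

From the compounds shown here alone, whether a carboxylic acid or a phenethylamino group on that carbonyl carbon would give a similar value remains open. So does the effect of a shorter or longer chain on the amine.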